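The source may report more compounds than this note shows. Statements on the series, on what has been measured and on what is new or still open speak of the compounds shown alone.

In an ADME assay on HepG2 cells (Homo sapiens) for cytotoxicity, read by resazurin assay, with a stated time of 24 h (a lower number here means that less compound is tolerated, a higher number that more compound is tolerated), compound 1 `CCN(CC)C(=O)c1c(CCc2ccc3ccccc3c2)cccc1OC` gives 35800 nM. Compound 2 `O=C(O)c1c(O)cccc1CCc1ccc2ccccc2c1` reaches the limit of > 100000 nM in this assay, which is a limit and not a number. Compound 3 `O=C(O)c1c(O)cccc1CCc1ccccc1` likewise sits at the limit of > 100000 nM in this assay. Compound 2 thus stands at the limit of > 100000 nM in this assay, at which 2 of the 3 values shown sit, without a number of its own to compare against. Compound 4 `O=C(O)c1c(O)cc(Cl)cc1CCc1ccc2ccccc2c1` differs from compound 2 by chloro in place of hydrogen on an aromatic carbon. Within the data shown here, no step between measured compounds is available to guide the size of the change in this assay, and the expectation is that compound 4 stays close to compound 2, with no step beyond the scatter or at most a small move toward lower tolerance. Compound 4 is therefore expected to give about 90000 nM in this assay, estimated to lie between 35000 nM and 250000 nM, which means an expected at least 1.1-fold lower number from compound 2 to compound 4 (0.04 log units; that floor lies within the scatter).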

Compound 4, half-maximal cytotoxic concentration: 35000 nM
Beside the measured number, compound 4's estimate is 2.6-fold (0.41 log units) above it; the measured number falls inside the stated range.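

In this assay, among these compounds, chloro in place of hydrogen at this position, para to a carboxy group and meta to a hydroxy group, gives the first step that can be read on this core: an at least 2.8-fold lower number from compound 2 to compound 4 (0.45 log units; beyond the scatter). Among the compounds shown here, compound 4 is also the first of the carboxy-bearing compounds to give a number rather than a limit. The step is only a floor, since compound 2 has no number of its own: the limit of > 100000 nM in this assay, at which 2 of the 4 values shown sit.

As far as these compounds go, whether a fluoro, methyl or methoxy group at this position would lower the number too stays open. So does whether chloro in place of hydrogen would move compound 3 in the same way.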